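A Biaryl Swap in a Bile Acid Receptor Series

The source may report more compounds than this note shows. Statements on the series, on what has been measured and on what is new or still open speak of the compounds shown alone.

Measured so far:
- compound 1, `COC(=O)/C=C/c1cccc(N(Cc2ccc(/C=C/c3cccc(C(F)(F)F)c3)cc2)C(=O)NC(C)C)c1`: 932 nM
- compound 2, `COC(=O)/C=C/c1cccc(N(Cc2ccc(-c3ccc(SC)cc3)cc2)C(=O)C(C)C)c1`: 51 nM
- compound 3, `COC(=O)/C=C/c1cccc(N(Cc2ccc(-c3ccc(OC(F)(F)F)cc3)cc2)C(=O)C(C)C)c1`: 219 nM

In an assay on isolated protein with Bile acid receptor (Homo sapiens) as the target (on this read-out higher numbers stand for an effect only at larger amounts of compound and lower numbers for an effect already at smaller amounts), compound 1 gives 932 nM, the highest of the three numbers. Compound 3 stands nearest to it, and compound 2 furthest, both with lower numbers beyond the scatter. Among the compounds with values here, the one measured step, a 4.3-fold higher number from compound 2 to compound 3 (0.63 log units; beyond the scatter), concerns a group on the far aromatic ring of a biaryl and is described as modest.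

Compound 4, `COC(=O)/C=C/c1cccc(N(Cc2ccc(-c3c(OC)cccc3OC)cc2)C(=O)NC(C)C)c1`, is not yet measured. It differs from compound 1 by 2,6-dimethoxyphenyl in place of 2-(3-(trifluoromethyl)phenyl)ethenyl on an aromatic carbon, placed on an aromatic carbon para to a large group. Within the data shown here, no measured step bears directly on this change: compounds 2 and 3 carry a biaryl as compound 4 does, but they also differ from compound 1 in the amide portion, so their gap to compound 1 cannot be read as a single step. Since compound 2 with 51 nM and compound 3 with 219 nM both lie lower than compound 1, a biaryl is expected to bring a lower number, by a step of about a 2.3-fold lower number from compound 1 to compound 4 (0.37 log units; beyond the scatter). Compound 4 is therefore expected at roughly 400 nM, within a range of 120 nM to 1500 nM.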

Compound 4, half-maximal effective concentration: 561 nM
Compound 4: middle estimate off by 1.4-fold (0.15 log units), on the low side; measured number inside the range.
By their numbers in this assay, from the lowest: compound 2; then compound 3; then compounds 4 and 1 (each within the scatter of the next).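

In this assay, replacing 2-(3-(trifluoromethyl)phenyl)ethenyl with 2,6-dimethoxyphenyl gives a 1.7-fold lower number from compound 1 to compound 4 (0.22 log units; within the scatter), so this exchange does not separate the two compounds. Within the data shown here, this is the first view of a change at this position, on an aromatic carbon para to a large group, with the rest of the molecule held constant; compound 2 and compound 3 differ from compound 1 in the amide portion as well. Here, the loss of the double bond and the trifluoromethyl group and the arrival of two methoxy groups leave the number within the scatter, and no other measurement offers an explanation for this result.

The compounds shown leave open how much of the lower numbers of compound 2 and compound 3 belongs to the amide portion and how much to the biaryl. They also leave open whether an aminophenyl or pyridyl group at this position, or a carboxylic acid in place of the methyl ester, would move the number beyond the scatter.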